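The source may report more compounds than this note shows. Statements on the series, on what has been measured and on what is new or still open speak of the compounds shown alone.

Measured in an in vitro ADME assay on microsomes from liver (Homo sapiens) for metabolic stability; a lower number here means slower removal, a higher number faster removal of the compound:
- compound 1 (`CC(C)Nc1nccc(-c2c[nH]nc2C2CCCCO2)n1`): 0.021 mL/min/kg
- compound 2 (`CC(C)Nc1nccc(-c2cn[nH]c2)n1`): 0.021 mL/min/kg

On these numbers, compound 2 stands level with compound 1. Compound 3 (`CC(C)Nc1nccc(-c2c[nH]nc2C2CCOCC2)n1`) differs from compound 2 by one change, (oxan-4-yl in place of hydrogen on an aromatic carbon), with oxan-4-yl in place of hydrogen on an aromatic carbon. Among the measured compounds shown here, the one measured step that bears on it is no change at the digits printed from compound 1 to compound 2 (within the scatter), where hydrogen takes the place of oxan-2-yl on an aromatic carbon. That step stays within the scatter, so no step beyond the scatter is expected in this assay here. The expected step is no change at the digits printed from compound 2 to compound 3 (within the scatter). Compound 3 is estimated at 0.021 mL/min/kg, with an expected range of 0.011 mL/min/kg to 0.042 mL/min/kg.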

Compound 3, clearance: 0.018 mL/min/kg
For compound 3 the middle estimate is 1.2-fold (0.07 log units) above the measured one, and the stated range covers the measured number.
By their numbers in this assay, from the lowest: compounds 3, 1 and 2 (each within the scatter of the next).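

Placing oxan-4-yl on this aromatic carbon, where compound 2 carries hydrogen, gives (a 1.2-fold lower number from compound 2 to compound 3 (0.07 log units; within the scatter)) in this assay, and oxan-4-yl in place of oxan-2-yl gives (a 1.2-fold lower number from compound 1 to compound 3 (0.07 log units; within the scatter)). At this position, then, neither adding this ring nor changing its point of attachment moves the clearance beyond the scatter. No supporting finding is available to explain this. Still open, going by these compounds, is whether an amine, a carboxylic acid or a longer chain on this carbon would produce a step beyond the scatter.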